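Nitro and Bromo Variants of a Sulfonylurea Core

The source may report more compounds than this note shows. Statements on the series, on what has been measured and on what is new or still open speak of the compounds shown alone.

Three compounds were measured in a functional assay on HT-29 cells (Homo sapiens) for antiproliferative activity, read by MTT assay, with a stated time of 24 h, tested at 10 uM; on this read-out lower numbers stand for less inhibition and higher numbers for more inhibition at the one concentration tested (going by the name of the read-out). Compound 1 `O=C(NS(=O)(=O)c1ccccc1)n1ccc2cccnc21` gives 23.6% in this assay. Compound 2 `O=C(NS(=O)(=O)c1cccc([N+](=O)[O-])c1)n1ccc2cccnc21` gives 18.9%, and compound 3 `O=C(NS(=O)(=O)c1ccccc1)n1ccc2cc(Br)cnc21` gives 14.6%. Compound 3 holds the lowest of the three numbers, yet its gaps to compound 2 and to compound 1 both lie within the scatter, so no order among them can be claimed. Compound 4 `O=C(NS(=O)(=O)c1cccc([N+](=O)[O-])c1)n1ccc2cc(Br)cnc21` differs from compound 3 by nitro in place of hydrogen on an aromatic carbon. The same change was already seen in a number 4.7 percentage points lower from compound 1 to compound 2 (within the scatter), a step within the scatter. For compound 4 a step of a number 2.6 percentage points lower from compound 3 to compound 4 (within the scatter) is therefore expected, no larger than the scatter. Compound 4 is estimated at 12%, between 2% and 24%.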

Compound 4, a percentage reported as inhibition, at one concentration (the size of the read-out at that concentration, not a potency): 58.5%
Compound 4: middle estimate off by 46.5 percentage points, on the low side; the measured number lies above the stated range.
By their numbers in this assay, from the lowest: compounds 3, 2 and 1 (each within the scatter of the next); then compound 4.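

In this assay the two changes do not simply add up when they are combined: nitro in place of hydrogen gives a number 43.9 percentage points higher from compound 3 to compound 4 (beyond the scatter), and bromo in place of hydrogen gives a number 39.6 percentage points higher from compound 2 to compound 4 (beyond the scatter). Within the data shown here, what nitro on this aromatic carbon does depends on the core that carries it, which the earlier compounds could not show: the same change on two cores in this assay, a number 4.7 percentage points lower (within the scatter) from compound 1 to compound 2 and a number 43.9 percentage points higher (beyond the scatter) from compound 3 to compound 4, 48.6 percentage points apart, beyond the scatter of two such steps. The bromo change likewise depends on the presence of the nitro: the same change on two cores in this assay, a number 9 percentage points lower (within the scatter) from compound 1 to compound 3 and a number 39.6 percentage points higher (beyond the scatter) from compound 2 to compound 4, 48.6 percentage points apart, beyond the scatter of two such steps.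

The compounds shown leave open whether the rise belongs to nitro alone or would also appear with an amine or a carboxylic acid at that place in a compound that keeps the bromo. They also leave open whether chloro could stand in for bromo.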